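Demethylation at the shared core in a chalcone pair

The source may report more compounds than this note shows. Statements on the series, on what has been measured and on what is new or still open speak of the compounds shown alone.

Compound 1 `COc1cc(OC)c(C(=O)/C=C/c2ccccc2OC)c(OC)c1` is the reference point of this small set. In a functional assay on Huh-7 cells (Homo sapiens) for cytotoxicity, with a stated time of 48 h (a lower number here means a stronger inhibitor, a higher number a weaker inhibitor), compound 1 gives 9800 nM. Compound 2 `COc1cccc(/C=C/C(=O)c2c(OC)cc(OC)cc2OC)c1` differs from it only in the aryl group on the double-bonded chain: 3-methoxyphenyl in place of 2-methoxyphenyl on a double-bonded chain carbon bound to a double-bonded chain carbon. In this assay compound 2 gives 8900 nM, and the step is a 1.1-fold lower number from compound 1 to compound 2 (0.04 log units; within the scatter), so the two cores are not told apart by this read-out.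

Compound 3 `COc1cc(O)c(C(=O)/C=C/c2ccccc2OC)c(OC)c1` carries a hydroxy in place of one methoxy on the core of compound 1: hydrogen in place of methyl on an oxygen on an aromatic ring. For compound 3 this assay reports only a limit, > 20000 nM. The step from compound 1 is therefore an at least 2.0-fold higher number from compound 1 to compound 3 (0.30 log units; that floor lies within the scatter); its size cannot be pinned down more closely because the limit of > 20000 nM in this assay, at which 1 of the 3 values shown sits, caps the measurement on the weaker side.

Compound 4 `COc1cccc(/C=C/C(=O)c2c(O)cc(OC)cc2OC)c1` is not yet measured. It stands to compound 2 as compound 3 stands to compound 1: hydrogen in place of methyl on an oxygen on an aromatic ring. The place of the change reads the same in both pairs, so this is the same change made on the other core. On the core of compound 1 that change gave an at least 2.0-fold higher number from compound 1 to compound 3 (0.30 log units; that floor lies within the scatter). Since the two cores give values within the scatter of each other, a step of similar size is expected in this assay: a 2.0-fold higher number from compound 2 to compound 4 (0.31 log units; beyond the scatter). On that basis compound 4 is estimated at 18000 nM, with a plausible span from 9000 nM to 40000 nM, and a real chance that only a limit is reported for compound 4.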

Compound 4, half-maximal inhibitory concentration: 15000 nM
The estimate for compound 4 lay 1.2-fold (0.08 log units) above the measured number, and the stated range covers the measured number.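

Carried to the core of compound 2, methoxy to hydroxy gives a 1.7-fold higher number from compound 2 to compound 4 (0.23 log units; within the scatter) in this assay, so this pair alone does not establish an effect of the change on the cytotoxicity read-out. The steps on the two cores point the same way as far as they can be read, which is compatible with the change carrying over from one core to the other, but two pairs are a narrow basis, and neither shows a step that is firmly beyond the scatter: the same change on two cores in this assay, an at least 2.0-fold higher number (0.30 log units; that floor lies within the scatter) from compound 1 to compound 3 and a 1.7-fold higher number (0.23 log units; within the scatter) from compound 2 to compound 4; the limit leaves it open whether they differ. Compound 3 is known only as a limit: the limit of > 20000 nM in this assay, at which 1 of the 4 values shown sits.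

The compounds shown leave open whether methoxy to hydroxy reads the same at the other methoxy groups of the shared core, or at the methoxy on the aryl group of the chain. They also leave open how an amine or a longer alkoxy chain would read in place of the hydroxy on the aromatic ring, and whether either replacement would give a step that stands clear of the scatter on both cores.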